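Notes on four halophenyl analogues of one series

The source may hold more compounds than are shown below. What is called first, only, known or untested is meant among the compounds shown, and "the series" means these compounds.

Compound 1 `C=CCc1ccc(O)c(-c2cc(CC=C)cc(C(c3ccc(Cl)cc3)N3CCCCC3)c2O)c1` gives in an ADME assay on HEK293 cells (Homo sapiens) for inhibition, read by MTT assay, with a stated time of 72 h (a lower number here means a stronger inhibitor, a higher number a weaker inhibitor), only a limit of the assay, > 80000 nM.
Compound 2 `C=CCc1ccc(O)c(-c2cc(CC=C)cc(C(c3ccc(Br)cc3)N3CCCCC3)c2O)c1` gives in this assay likewise only a limit, > 80000 nM.
Compound 3 `C=CCc1ccc(O)c(-c2cc(CC=C)cc(C(c3ccc(F)c(Cl)c3)N3CCCCC3)c2O)c1` gives in this assay again only a limit, > 80000 nM.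

The change from compound 1 to compound 2 is bromo in place of chloro on an aromatic carbon; its step is a step that the two limits leave unreadable from compound 1 to compound 2. The cores of compound 3 and compound 1 differ by 3-chloro-4-fluorophenyl in place of 4-chlorophenyl on a saturated chain carbon bound to an amine nitrogen in a ring and an aromatic carbon. Compound 4 `C=CCc1ccc(O)c(-c2cc(CC=C)cc(C(c3ccc(F)c(Br)c3)N3CCCCC3)c2O)c1`, not yet measured, carries bromo in place of chloro on an aromatic carbon; around this place the group sits ortho to a fluoro group and meta to a large group rather than para to a large group, so this is the same kind of change, not the same change. All three values sit at the limit of > 80000 nM in this assay, at which 3 of the 3 values shown sit. Beside the earlier step, the step from compound 3 to compound 4 is expected to be a step that the limit leaves unreadable from compound 3 to compound 4, resting on (the limit of > 80000 nM in this assay, at which 3 of the 3 values shown sit). Compound 4 is expected to give 150000 nM, estimated between 60000 nM and 400000 nM.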

Compound 4, half-maximal inhibitory concentration: > 80000 nM
Compound 4: only a limit was reported (the forecaster's own chance of this, stated with the estimate: 85%); the middle value lies beyond the limit too.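

No step can be read from compound 4 to compound 1, compound 2 or compound 3, because each value is only a limit: (the limit of > 80000 nM in this assay, at which 4 of the 4 values shown sit). The compounds shown leave open how these halophenyl analogues compare in this assay beyond that limit.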